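A few compounds are considered here, and "the series" means these few. Any claim that something is new, unique, unknown or untested is made for them only; others in the source may bear on it.

Of the compounds shown here, three have so far been measured in an assay on blood for inhibition of Indoleamine 2,3-dioxygenase 1 (Homo sapiens), read by mass spectrometry, with a stated time of 18 h; on this read-out lower numbers stand for stronger inhibition and higher numbers for weaker inhibition. Compound 1 `CCC(c1nc2ncc(Cl)cc2[nH]1)[C@H]1CC[C@@H](c2ccnc3ccc(F)cc32)CC1` gives 6 nM in this assay, the lowest of the three numbers. Compound 3 `CCC(c1nc2ccc(Cl)cc2[nH]1)[C@H]1CC[C@H](Oc2ccnc3ccccc23)CC1` gives 36 nM in this assay, a higher number by a gap that is beyond the usual scatter. Compound 2 `CCC(Nc1nnc(-c2ccc(OC)cc2)o1)[C@H]1CC[C@H](Oc2ccnc3ccccc23)CC1` gives 459 nM in this assay, far higher still, and so compound 1 stands alone as the strongest inhibitor among the three. Each of these compounds differs from the others in more than one place, so none of their gaps can be pinned on a single change.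

Compound 4 `CCC(c1nc2ncc(Cl)cc2[nH]1)[C@H]1CC[C@@H](c2ccnc3ccc(C(F)(F)F)cc32)CC1` has not yet been measured. It differs from compound 1 in one place: trifluoromethyl in place of fluoro on an aromatic carbon. Within the data shown here, no measured pair in this set shows what such a swap does on its own, so the expectation rests only on the size of the change and on the standing of compound 1. Both groups are small and carry no donor or acceptor; a shift within the usual scatter is expected, as a 1.5-fold higher number from compound 1 to compound 4 (0.18 log units; within the scatter). For compound 4 the estimate in this assay is 9 nM, within a range from 3 nM to 27 nM.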

Compound 4, half-maximal inhibitory concentration: 21 nM
Compound 4: the middle estimate sits 2.3-fold (0.37 log units) below what was measured, and the stated range covers the measured number.
By their numbers in this assay, from the lowest: compound 1; then compounds 4 and 3 (each within the scatter of the next); then compound 2.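

Among these compounds, the swap of fluoro for trifluoromethyl is the first single change in this set whose effect can be read on its own: in this assay it gives a 3.5-fold higher number from compound 1 to compound 4 (0.54 log units; beyond the scatter) and this modest step lies beyond the usual scatter. This aromatic carbon therefore does not treat the two groups alike, even though neither group carries a hydrogen-bond donor or acceptor, neither has a ring and neither has a net charge; what separates them in the computed comparison is the added carbon and the extra fluorine atoms. No measurement at hand explains why the number rises.

Among the compounds shown here, with only two groups seen at this carbon, a single step cannot show whether the number tracks the heavy-atom count, the fluorine count or something else entirely. As far as these compounds go, a plain hydrogen, a methyl, a nitrile or an amine at the same carbon would help to separate these readings, and it remains open whether the same swap would give a similar step on a different core.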